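Swapping the aryl group on a kinase-type amide scaffold

The source may report more compounds than this note shows. Statements on the series, on what has been measured and on what is new or still open speak of the compounds shown alone.

Three compounds sharing one core were examined in a functional assay on U-87MG ATCC cells (Homo sapiens) for cytotoxicity, read by MTT assay, with a stated time of 72 h; on this read-out higher numbers stand for weaker inhibition and lower numbers for stronger inhibition. Compound 1 `COc1cc2c(Oc3ccc(NC(=O)c4cc(-c5ccc(F)cc5)ccn4)cc3F)ccnc2cc1OCCCN1CCCCC1` carries a 4-fluorophenyl group on the pyridine amide and a piperidine at the end of its side chain, and in this assay compound 1 gives 12500 nM. Compound 2 `COc1cc2c(Oc3ccc(NC(=O)c4cc(-c5ccc(F)cc5)ccn4)cc3F)ccnc2cc1OCCCN1CCN(C)CC1` keeps the same 4-fluorophenyl group but ends its side chain in a methylpiperazine; in this assay compound 2 gives "not determined" (no result reported), so no number is available for it. Compound 3 `COc1cc2c(Oc3ccc(NC(=O)c4cc(-c5ccc(C)cc5)ccn4)cc3F)ccnc2cc1OCCCN1CCCC1` bears a 4-methylphenyl group and a pyrrolidine on the side chain, and in this assay compound 3 gives 560 nM. Compound 3 therefore holds the lowest number of the two that were obtained, and the gap to compound 1 lies well beyond the scatter of the assay. Because compound 1 and compound 3 differ in two places at once, the numbers alone do not tell which change matters.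

Compound 4 `COc1cc2c(Oc3ccc(NC(=O)c4cc(-c5ccccc5F)ccn4)cc3F)ccnc2cc1OCCCN1CCCC1` changes only the aryl group: 2-fluorophenyl in place of 4-methylphenyl on an aromatic carbon. Nothing in the measured set isolates this kind of swap, so the expected step from compound 3 to compound 4 is estimated to be modest, a 2.7-fold higher number from compound 3 to compound 4 (0.43 log units; beyond the scatter), towards a somewhat higher number. Compound 4 is therefore expected to give about 1500 nM in this assay, with a plausible range from 400 nM to 6000 nM.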

Compound 4, half-maximal inhibitory concentration: 610 nM
Compound 4: the middle estimate sits 2.5-fold (0.39 log units) above what was measured, and the stated range covers the measured number.
By their numbers in this assay, from the lowest: compounds 3 and 4 (each within the scatter of the next); then compound 1.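

Going by these compounds alone, replacing 4-methylphenyl with 2-fluorophenyl on an aromatic carbon, opposite the ring nitrogen, gives a 1.1-fold higher number from compound 3 to compound 4 (0.04 log units; within the scatter) in this assay and is the first change in this set made in a single place. With the pyrrolidine side chain and the rest of the molecule held constant, two aryl groups with the same heavy-atom count and no hydrogen-bond donors or acceptors give values that cannot be told apart, even though the substituent differs in both identity and location on the phenyl ring. The data shown give no measured explanation for this close match.

Within the data shown here, what remains open is how much of the gap between compound 1 and compound 3 comes from the amine at the end of the side chain, since these compounds differ in two places and no single-place pair here separates the piperidine from the pyrrolidine. Going by these compounds, it is also open how this position would respond to a group quite unlike these two aryl groups, such as an unsubstituted pyridine ring or a carboxylic acid.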